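Isoxazole aryl swap toward a methylsulfonyl group

A few compounds are considered here, and "the series" means these few. Any claim that something is new, unique, unknown or untested is made for them only; others in the source may bear on it.

Compounds measured: compound 1 `Cc1cc(OCc2c(-c3cc[nH]c(=O)c3Cl)noc2C(C)C)ccc1-c1ccc2c(C(=O)O)cn(C)c2c1`, 1100 nM; compound 2 `COc1ccccc1-c1noc(C(C)C)c1COc1ccc(/C=C/c2cccc(C(=O)O)c2)c(Cl)c1`, 250 nM.

In an assay on isolated protein for displacement of a labelled ligand from Bile acid receptor (Homo sapiens), read by scintillation proximity assay and radioligand binding (a higher number here means a weaker inhibitor, a lower number a stronger inhibitor), compound 2 gives 250 nM, the lowest of the two numbers, while compound 1 gives 1100 nM, a gap that lies beyond the scatter. Compound 3 `CC(C)c1onc(-c2ccc(S(C)(=O)=O)cc2Cl)c1COc1ccc(/C=C/c2cccc(C(=O)O)c2)c(Cl)c1` differs from compound 2 by 2-chloro-4-(methylsulfonyl)phenyl in place of 2-methoxyphenyl on an aromatic carbon, next to the ring nitrogen of the shared core. Within the data shown here, no measured pair shows this change, so the step is unknown. The estimate for compound 3 is a step of a 1.3-fold lower number from compound 2 to compound 3 (0.10 log units; within the scatter), within the scatter of compound 2, giving an expected value of 200 nM with a range from 60 nM to 700 nM.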

Compound 3, half-maximal inhibitory concentration: 170 nM
Compound 3: the middle estimate sits 1.2-fold (0.07 log units) above what was measured; the measured number falls inside the stated range.
By their numbers in this assay, from the lowest: compounds 3 and 2 (each within the scatter of the next); then compound 1.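

Among these compounds, compound 2 and compound 3 form the first pair here that differs in one place, which compounds 1 and 2 could not offer. Putting 2-chloro-4-(methylsulfonyl)phenyl in place of 2-methoxyphenyl on this aromatic carbon gives a 1.5-fold lower number from compound 2 to compound 3 (0.17 log units; within the scatter) in this assay, so the position takes the entering group of 11 heavy atoms, against 8 for the one leaving, without a change beyond the scatter. Nothing available explains this result. The compounds shown leave open how the chlorine and the methylsulfonyl group each count alone, and whether a cyclohexyl group or an amine on this carbon would hold the number.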